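Acetyl in place of trifluoromethoxy: compound 3 to compound 4

This account rests on a few compounds, and the source may have more. Where it says the series, first, only, none or still open, it means among the compounds named here.

The series shares the core of compound 1 `Oc1ccccc1CNc1ccc(-c2ccccc2)cc1`, which in a functional assay on Jurkat cells (Homo sapiens) for activation, with a stated time of 24 h (a higher number here means that more compound is needed for the effect, a lower number that less compound is needed), gives 1820 nM. Among the measured compounds shown here, compound 2 `Cc1ccc(-c2ccc(NCc3ccccc3O)cc2)cc1` carries a methyl on an aromatic carbon and in this assay gives 3790 nM; the step of a 2.1-fold higher number from compound 1 to compound 2 (0.32 log units; beyond the scatter) is the only measured change at a substituent of this kind. Compound 3 `Oc1ccccc1CNc1ccc(-c2ccc(OC(F)(F)F)cc2)cc1` bears a trifluoromethoxy on an aromatic carbon and in this assay is reported as "not active" (no number reported), so no single number stands for compound 3. Compound 4 `CC(=O)c1ccc(-c2ccc(NCc3ccccc3O)cc2)cc1` differs from compound 3 by acetyl in place of trifluoromethoxy on an aromatic carbon of a six-membered aromatic ring of carbon only, para to a large group. For the measured compounds named here, only the step from compound 1 to compound 2 bears on a change at this place, and it was modest; compound 3 gives no number at all. Nothing measured points to acetyl doing better than the unsubstituted parent, so a higher number than that of compound 1, or again no number, is expected in this assay. Compound 4 is therefore estimated in this assay at 6000 nM, with a range from 2000 nM to 30000 nM.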

Compound 4, half-maximal effective concentration: "not active" (no number reported)
Compound 4 has no reported number here; the estimate stays without a comparison.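

In this assay compound 3 gives "not active" (no number reported) and compound 4 gives "not active" (no number reported) so no step can be read between them. The compounds shown leave open whether any group at this place other than methyl keeps a measurable value. No measurement shown bears on this result.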